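Moving one methyl group: from compound 2 to compound 4

The compounds below may be only part of what the source reports. "The series", "measured", "known", "first", "only" and "open" are said of these compounds alone.

Values from a functional assay on K562 cells (Homo sapiens) for inhibition, read by trypan blue exclusion, with a stated time of 72 h (a lower number here means a stronger inhibitor, a higher number a weaker inhibitor), follow
- compound 1 `Cn1c(=O)c(S(=O)(=O)c2ccc(F)cc2F)cc2cnc(Nc3cccc4[nH]ccc34)nc21` gives 1500 nM
- compound 2 `Cn1ccc2cc(Nc3ncc4cc(S(=O)(=O)c5ccc(F)cc5F)c(=O)n(C)c4n3)ccc21` gives 750 nM
- compound 3 `COC(=O)Cn1ccc2cc(Nc3ncc4cc(S(=O)(=O)c5ccc(F)cc5F)c(=O)n(C)c4n3)ccc21` gives 5000 nM

The low end of these numbers is held by compound 2 together with compound 1, and their values lie within the scatter of each other. Compound 4 `Cc1cc2cc(Nc3ncc4cc(S(=O)(=O)c5ccc(F)cc5F)c(=O)n(C)c4n3)ccc2[nH]1` has the same atoms as compound 2, joined differently (2-methyl-1H-indol-5-yl in place of 1-methyl-1H-indol-5-yl on a nitrogen on an aromatic ring). In words, 2-methyl-1H-indol-5-yl takes the place of 1-methyl-1H-indol-5-yl on a nitrogen on an aromatic ring.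

Two measured steps offer guidance, and neither makes this exact change. The nearer guide (a 2.0-fold lower number from compound 1 to compound 2 (0.30 log units; within the scatter)) swapped 1H-indol-4-yl for 1-methyl-1H-indol-5-yl. The larger step (a 6.7-fold higher number from compound 2 to compound 3 (0.82 log units; beyond the scatter)) added methoxycarbonyl, a group absent from compound 4, so it bears less directly. In this assay, no change beyond the scatter is therefore expected, and the estimated step is small (a 1.2-fold higher number from compound 2 to compound 4 (0.08 log units; within the scatter)). Compound 4 is estimated at 900 nM (expected range 300 nM to 2700 nM).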

Compound 4, half-maximal inhibitory concentration: 750 nM
For compound 4 the middle estimate is 1.2-fold (0.08 log units) above the measured one; low and high end bracket the measured number.
By their numbers in this assay, from the lowest: compounds 2, 4 and 1 (each within the scatter of the next); then compound 3.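

In this assay, shifting the methyl group so that 2-methyl-1H-indol-5-yl replaces 1-methyl-1H-indol-5-yl gives no change at the digits printed from compound 2 to compound 4 (within the scatter), although the entering group counts 1 hydrogen-bond donor and the leaving group none. For the compounds shown here, at this place on the nitrogen, then, this read-out does not separate the two methyl placements or the two donor counts, and the earlier compounds could not show this. The step from the 1H-indol-4-yl group (a 2.0-fold lower number from compound 1 to compound 4 (0.30 log units; within the scatter)) also stays within the scatter, and nothing measured here offers a reason for these results.

On these data alone, it remains open whether 1H-indol-5-yl, which has no methyl group, would read like compound 2 and compound 4. Also open, as far as these compounds go, is how an aminomethyl group or a carboxylic acid in place of the methyl would behave.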